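A few compounds are considered here, and "the series" means these few. Any claim that something is new, unique, unknown or untested is made for them only; others in the source may bear on it.

Two measured compounds are in hand and do not share a core. Compound 1, `COc1ccc(-c2cn(CC(=O)Nc3nc4ccccc4s3)nn2)cc1`, gives 1330 nM in a functional assay on BMDM cells (Mus musculus, strain C57BL/6) for inhibition, with a stated time of 2 days; a higher number here means a weaker inhibitor, a lower number a stronger inhibitor. Compound 2, `COc1cccc(-c2cn(-c3ccc(C(F)(F)F)cc3)nc2C(=O)N2CCN(c3ncccn3)CC2)c1`, belongs to a second series and in this assay gives > 30000 nM, which is a limit of the assay and not a number. What is known of compound 2 is therefore only (the limit of > 30000 nM in this assay, at which 1 of the 2 values shown sits). Going by the values given here, nothing connects the two series by a single change, so no measured step is available to lean on.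

Compound 3, `COc1cccc(-c2cn(-c3ccc(C(F)(F)F)cc3)nc2C(=O)NC2CCCCC2)c1`, is the next member of the second series and awaits measurement in this assay. It differs from compound 2 in one place: cyclohexylamino in place of 4-(pyrimidin-2-yl)piperazin-1-yl on a carbonyl carbon. Among the compounds with values here, the only anchor for compound 3 is a limit, so the size of any step can be read from the structures alone, and with a single limit as the starting point the direction stays open. The expected step is an at least 2.0-fold lower number from compound 2 to compound 3 (0.30 log units; that floor lies within the scatter), at most modest beyond the scatter. Compound 3 is estimated at 15000 nM in this assay, within 3000 nM to 30000 nM, with a real chance that the assay again returns only a limit.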

Compound 3, half-maximal inhibitory concentration: > 30000 nM
Compound 3: no number, only a limit; the forecaster's own chance of this, stated with the estimate: 45%; middle value at least 2.0-fold (0.30 log units) away from the limit.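

In this assay compound 3 gives > 30000 nM, a limit of the assay and not a number. Compound 2 also stands only at a limit, and no step can be read between compound 2 and compound 3. From the compounds shown here alone, how cyclohexylamino compares with 4-(pyrimidin-2-yl)piperazin-1-yl on the carbonyl carbon remains open.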